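From ethyl to isopropyl: compound 1 to compound 4

The source may hold more compounds than are shown below. What is called first, only, known or untested is meant among the compounds shown, and "the series" means these compounds.

Measured values in a physicochemical assay for solubility, at pH 6.8 (on this read-out lower numbers stand for lower solubility and higher numbers for higher solubility), are as follows.
- Compound 1 `CCNC(=O)c1nc(-c2ccc(CN(C)C)cc2)cnc1N` gives > 1000000 nM (a limit)
- Compound 2 `CCN(CC)Cc1ccc(-c2cnc(N)c(C(=O)NC[C@@](C)(O)C(F)(F)F)n2)cc1` gives > 1000000 nM (a limit)
- Compound 3 `CC(C)N1CCN(Cc2ccc(-c3cnc(N)c(C(=O)N[C@H]4CC[C@H](O)CC4)n3)cc2)CC1` gives 830000 nM

Compound 1 stands at the limit of > 1000000 nM in this assay, at which 2 of the 3 values shown sit, and this is a limit, not a number. Compound 4 `CC(C)NC(=O)c1nc(-c2ccc(CN(C)C)cc2)cnc1N` keeps the core of compound 1 and turns ethyl to isopropyl (methyl in place of hydrogen on a saturated chain carbon bound to an amide-type nitrogen and a saturated chain carbon). Going by the values given here, no measured pair of compounds shows this change alone. The only exact figure is that of compound 3 (830000 nM), and it is no direct guide. In this assay no step beyond the usual scatter is expected. The estimated move (an at least 1.1-fold lower number from compound 1 to compound 4 (0.04 log units; that floor lies within the scatter)) is expected to stay small. For compound 4 the estimate is 900000 nM (expected range 450000 nM to 1500000 nM).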

Compound 4, solubility: > 1000000 nM
Compound 4: a limit, no number (the forecaster's own chance of this, stated with the estimate: 60%); middle value at least 1.1-fold (0.04 log units) from the limit.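

Going by these compounds alone, compound 1 and compound 4 both give only a limit in this assay, not a number, and no step between them can be read. The compounds shown leave open whether turning ethyl to isopropyl shifts this read-out at all.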